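Replacing Phenyl by Cyclohexyl at the Amide-Type Nitrogen

This account rests on a few compounds, and the source may have more. Where it says the series, first, only, none or still open, it means among the compounds named here.

Of the compounds shown here, three sharing one core have been tested in a functional assay on HEK293T cells for agonist activity at histamine H2 receptor (Homo sapiens), read by beta-arrestin recruitment; a higher number here means a larger maximal response, a lower number a smaller maximal response. Compound 1 `Cc1nc(N)sc1CCCN/C(N)=N/C(=O)N[C@@H](C)c1ccccc1` gives 0.46, compound 2 `CCCCCCNC(=O)/N=C(\N)NCCCc1sc(N)nc1C` gives 0.28, and compound 3 `Cc1nc(N)sc1CCCN/C(N)=N/C(=O)Nc1ccccc1` gives 0.25. Among these, compound 3 holds the lowest number: compound 2 lies within the scatter of it, while compound 1 lies beyond it, as the step a number 0.21 lower from compound 1 to compound 3 (beyond the scatter) shows.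

Compound 4 `Cc1nc(N)sc1CCCN/C(N)=N/C(=O)NC1CCCCC1` differs from compound 3 in one place: cyclohexyl in place of phenyl on an amide-type nitrogen.

Going by the values given here, no measured step swaps phenyl for cyclohexyl, so the bearing comes from the neighbouring steps. Hexyl in place of 1-phenylethyl gave a number 0.18 lower from compound 1 to compound 2 (beyond the scatter), phenyl in place of 1-phenylethyl gave a number 0.21 lower from compound 1 to compound 3 (beyond the scatter), and phenyl in place of hexyl gave a number 0.030 lower from compound 2 to compound 3 (within the scatter). The last of these, which also sets a non-aromatic group against phenyl on the same nitrogen, stayed within the scatter. The change to cyclohexyl is therefore expected to bring nothing beyond the scatter, a number 0.050 higher from compound 3 to compound 4 (within the scatter). Compound 4 is accordingly estimated at 0.3, with a range from 0.18 to 0.44.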

Compound 4, intrinsic activity: the largest response reached, as a fraction of the reference agonist's: 0.43
Compound 4: the middle estimate sits 0.13 below what was measured, and the stated range covers the measured number.
By their numbers in this assay, from the lowest: compounds 3 and 2 (each within the scatter of the next); then compounds 4 and 1 (each within the scatter of the next).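

In this assay the saturation of the ring on the amide-type nitrogen proves to matter: with the same count of heavy atoms, all carbon, and no hydrogen-bond donors or acceptors on either group, cyclohexyl in place of phenyl gives a number 0.18 higher from compound 3 to compound 4 (beyond the scatter) and so separates two groups that differ only in being a non-aromatic or an aromatic ring. Cyclohexyl also parts from the open chain, with a number 0.15 higher from compound 2 to compound 4 (beyond the scatter) showing a gap that hexyl and phenyl had not shown between themselves. An aromatic ring in the substituent is thus not needed to reach the upper pair of compounds, since a number 0.030 lower from compound 1 to compound 4 (within the scatter) leaves cyclohexyl and 1-phenylethyl not told apart.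

Nothing at hand gives a reason for this difference between the two rings. From the compounds shown here alone, whether the higher response belongs to cyclohexyl alone or extends to other non-aromatic rings such as cyclopentyl or cycloheptyl on this nitrogen stays open, as does the outcome for cyclohexylmethyl, which would set the ring one carbon further out.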